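Replacing the Amine-Bearing Ring with a Phenol Ring

This account rests on a few compounds, and the source may have more. Where it says the series, first, only, none or still open, it means among the compounds named here.

Compound 1 `COc1ccc(C(=O)/C=C/c2cc(OC)c(OC)c(OC)c2)c2c1C=CC(C)(C)O2` gives 9150 nM in a functional assay on SW-620 cells (Homo sapiens) for antiproliferative activity, read by MTT assay, with a stated time of 24 h; a higher number here means a weaker inhibitor, a lower number a stronger inhibitor.
Compound 2 `COc1ccc(C(=O)/C=C/c2ccc(N(C)C)cc2)c2c1C=CC(C)(C)O2` gives 570 nM in this assay.
Compound 3 `COc1ccc(C(=O)/C=C/c2ccc3ccccc3c2)c2c1C=CC(C)(C)O2` gives 2140 nM in this assay.

Among these three numbers compound 2 stands lowest. Its nearest neighbour is compound 3, and the gap between them lies beyond the scatter of repeated measurements; compound 1 is furthest away, also beyond the scatter. Compound 2 is therefore the strongest inhibitor of the three in this assay.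

Compound 4 `COc1ccc(C(=O)/C=C/c2cccc(O)c2)c2c1C=CC(C)(C)O2` shares the core of compound 2 and differs from it in one place: 3-hydroxyphenyl in place of 4-(dimethylamino)phenyl on a double-bonded chain carbon bound to a double-bonded chain carbon. For the measured compounds named here, no pair of measured compounds differs by only this kind of change, so the data give no direct precedent for it. The three measured compounds do show that the ring on the double-bonded chain carbon matters, since compound 1 and compound 3 both sit well above compound 2. On that basis the change is expected to weaken inhibition, and the step from compound 2 to compound 4 in this assay is estimated at a 4.4-fold higher number from compound 2 to compound 4 (0.64 log units; beyond the scatter). Compound 4 is expected to give 2500 nM, within a range from 900 nM to 8000 nM.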

Compound 4, half-maximal inhibitory concentration: > 10000 nM
Compound 4: no number, only a limit; the forecaster's own chance of this, stated with the estimate: 5%; middle value at least 4.0-fold (0.60 log units) from the limit.
By their numbers in this assay, from the lowest: compound 2; then compound 3; then compound 1. At a limit, above all of these: compound 4.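

Putting 3-hydroxyphenyl in place of 4-(dimethylamino)phenyl on a double-bonded chain carbon bound to a double-bonded chain carbon sharply weakens inhibition in this assay, with an at least 17-fold higher number from compound 2 to compound 4 (1.24 log units; beyond the scatter). The value of compound 4 is a limit and not a number: the limit of > 10000 nM in this assay, at which 1 of the 4 values shown sits. The three earlier compounds all gave numbers, so compound 4 is the only one shown whose ring at this place takes the read-out to the limit of this assay.

This single change removes the dimethylamino group and adds a hydroxyl group at once, so the compounds shown cannot tell which of the two accounts for the loss. From the compounds shown here alone, whether an unsubstituted phenyl, or a ring carrying a primary amine or a diethylamino group, would hold inhibition closer to that of compound 2 remains open.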